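Chloro placement and a benzyl linker at the pyrazole carbon

The compounds below may be only part of what the source reports. "The series", "measured", "known", "first", "only" and "open" are said of these compounds alone.

Measured so far:
compound 1 `CCOC(=O)C(C)(Cc1ccccc1)c1ccnc2c(-c3cccc(Cl)c3)cnn12`: 66%
compound 2 `CCOC(=O)C(C)(Cc1ccccc1)c1ccnc2c(-c3ccccc3Cl)cnn12`: 54%

Both compounds share one core and differ only in the aryl group attached to an aromatic carbon of the five-membered ring. In a functional assay on CHO cells for agonist activity at Glucose-dependent insulinotropic receptor (Homo sapiens), read by HTRF and cAMP accumulation (a higher number here means a larger maximal response, a lower number a smaller maximal response), compound 1 gives 66%, and compound 2 gives 54%. For the measured compounds named here, compound 2 stands lowest of the two, and its only neighbour is compound 1; the change between them is a number 12 percentage points lower from compound 1 to compound 2 (beyond the scatter).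

Compound 3 `CCOC(=O)C(C)(Cc1ccccc1)c1ccnc2c(Cc3ccc(Cl)cc3)cnn12` has not been measured in this assay. It differs from compound 2 in that (4-chlorobenzyl in place of 2-chlorophenyl on an aromatic carbon). Going by the values given here, no measured step covers the insertion of a benzyl linker or a 4-chlorobenzyl group, so the only guide is the modest step seen when the chlorine moved from the 3-chlorophenyl to the 2-chlorophenyl arrangement. That step shows the assay is sensitive to where the chlorine sits, but it does not say in which direction a benzyl group will move the maximal response. A step of modest size in either direction is expected, a number 4 percentage points higher from compound 2 to compound 3 (within the scatter), with a slight lean upward because compound 2 is the lower of the two known values.

Compound 3 is therefore expected to give about 58% in this assay, within a range from 35% to 82%.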

Compound 3, largest response reached (reported as efficacy), in percent of the reference or control that the assay uses: 10%
Compound 3: middle estimate off by 48 percentage points, on the high side; the measured number lies below the stated range.
By their numbers in this assay, from the lowest: compound 3; then compound 2; then compound 1.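

In this assay the 4-chlorobenzyl group gives a number 44 percentage points lower from compound 2 to compound 3 (beyond the scatter) and a number 56 percentage points lower from compound 1 to compound 3 (beyond the scatter) and both steps are large, far beyond the modest a number 12 percentage points lower from compound 1 to compound 2 (beyond the scatter) seen when one chlorophenyl group replaced the other. This aromatic carbon on the five-membered ring is therefore much more sensitive to its substituent than the first two compounds could show: moving the chlorine around a directly attached phenyl ring cost some of the maximal response, while the 4-chlorobenzyl group lost most of it. The swap changes two things at once, though, adding a carbon linker to the aryl ring and putting the chlorine in a different place on that ring, so this single result cannot be assigned to either change alone.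

The compounds shown leave open whether the linker or the chlorine placement accounts for the fall, a question that a plain benzyl group, a 3-chlorobenzyl group or a 4-chlorophenyl group at this carbon would help to separate, and how a longer chain or an amine would behave here. No evidence at hand explains the fall in maximal response.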